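This account rests on a few compounds, and the source may have more. Where it says the series, first, only, none or still open, it means among the compounds named here.

Measured so far:
- compound 1 `Nc1ccccc1NC(=O)c1ccc(CSC(=S)N2CCN(C3CCCCC3)CC2)cc1`: 89.9%
- compound 2 `Nc1ccccc1NC(=O)c1ccc(CSC(=S)N2CCc3cc([N+](=O)[O-])ccc32)cc1`: 29.5%
- compound 3 `Nc1ccccc1NC(=O)c1ccc(CSC(=S)N2CCc3ccc([N+](=O)[O-])cc32)cc1`: 42%

In a functional assay on A-375 cells (Homo sapiens) for antiproliferative activity, read by CCK-8 assay, with a stated time of 72 h, tested at 8 uM (a lower number here means a weaker effect, a higher number a stronger effect of the compound at the concentration tested), compound 1 stands highest of the three numbers. The nearest, compound 3, lies well below it, by a margin beyond the scatter of repeated measurements, and compound 2 lies further below still, also beyond the scatter. No two of the measured compounds differ in only one place, so none of them shows directly how large a single change can be.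

Compound 4 `Cc1ccc(N2CCN(C(=S)SCc3ccc(C(=O)Nc4ccccc4N)cc3)CC2)cc1` differs from compound 1 in one place: 4-methylphenyl in place of cyclohexyl on an amine nitrogen in a ring. The cyclohexyl group leaves and 4-methylphenyl enters on the amine nitrogen in the ring, with the rest of the shared core untouched. For the measured compounds named here, nothing among the measured compounds traces this exchange, so the expectation rests on compound 1 alone. A small downward step is expected, a number 11.9 percentage points lower from compound 1 to compound 4 (beyond the scatter), which may not exceed the scatter. Compound 4 is therefore estimated at 78%, in a range from 55% to 93%.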

Compound 4, a percentage reported as inhibition, at one concentration (the size of the read-out at that concentration, not a potency): 26.4%
The estimate for compound 4 lay 51.6 percentage points above the measured number; the measured number lies below the stated range.
By their numbers in this assay, from the lowest: compounds 4 and 2 (each within the scatter of the next); then compound 3; then compound 1.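

In this assay the group on the amine nitrogen in the ring turns out to matter greatly: 4-methylphenyl in place of cyclohexyl gives a number 63.5 percentage points lower from compound 1 to compound 4 (beyond the scatter) with the rest of the shared core untouched. This is the first single change among these compounds, and it shows that one exchange at this position can remove most of the effect seen for compound 1, even though neither group carries hydrogen-bond donors, hydrogen-bond acceptors or a net charge. There is no measurement at hand that explains the size of this drop.

The compounds shown do not separate the aromatic ring from its methyl group, a question that plain phenyl on the same nitrogen would address. As far as these compounds go, how a simple methyl group or a hydroxyethyl chain would fare at this position also stays open.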